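Trading 2-phenylethenyl for phenyl on a carbonyl carbon

This account rests on a few compounds, and the source may have more. Where it says the series, first, only, none or still open, it means among the compounds named here.

Two related compounds have been measured so far in a functional assay on HeLa cells (Homo sapiens) for cytotoxicity, read by MTT assay, with a stated time of 48 h; a higher number here means a weaker inhibitor, a lower number a stronger inhibitor. Compound 1 `O=C(/C=C/c1cccc(F)c1)Nc1ccc(CC2=CC(=O)OC2)cc1` gives 49000 nM, whereas compound 2 `C=C1OC(=O)C=C1Cc1ccc(NC(=O)/C=C/c2ccccc2)cc1` gives 7340 nM. Compound 2 therefore holds the lower of the two numbers, and the gap between them lies beyond the usual scatter. These two compounds differ in more than one place, so their gap cannot be credited to any single structural change.

The next compound to be tested is compound 3 `C=C1OC(=O)C=C1Cc1ccc(NC(=O)c2ccccc2)cc1`, which has phenyl in place of 2-phenylethenyl on a carbonyl carbon. Among the measured compounds shown here, no measured pair shows this change, so any forecast is only tentative. Compound 2, at 7340 nM, already has the lower number of the pair, so a change to it seems somewhat more likely to raise the number in this assay than to lower it. The expected shift is modest and may not clear the scatter, with an estimated step of a 2.0-fold higher number from compound 2 to compound 3 (0.31 log units; beyond the scatter) toward weaker inhibition. The estimated value for compound 3 is 15000 nM, with an expected range from 5000 nM to 50000 nM.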

Compound 3, half-maximal inhibitory concentration: 48300 nM
The estimate for compound 3 lay 3.2-fold (0.51 log units) below the measured number, within the range that was stated.
By their numbers in this assay, from the lowest: compound 2; then compounds 3 and 1 (each within the scatter of the next).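

In this assay, among the compounds shown here, putting phenyl in place of 2-phenylethenyl on a carbonyl carbon whose other neighbour is an amide-type nitrogen gives a 6.6-fold higher number from compound 2 to compound 3 (0.82 log units; beyond the scatter), the first comparison here in which only one place changes. A higher number means weaker inhibition, so this position is not indifferent to what it carries, and of these two groups 2-phenylethenyl goes with the lower number, even though both bring the same aromatic ring and only 2-phenylethenyl brings a double bond outside it. No measurement here bears on why the number moves with this change.

This single pair cannot separate the part played by that double bond from the part played by the size of the group, and a saturated 2-phenylethyl group on the same carbonyl carbon would be one way to pull the two apart. Also open, as far as these compounds go, is how other groups at this position would behave, such as a longer chain or a chain ending in an amine, and whether the step holds on other versions of the shared core.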